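Oxamic acid in place of carboxy on the aryl sulfide

A few compounds are considered here, and "the series" means these few. Any claim that something is new, unique, unknown or untested is made for them only; others in the source may bear on it.

Compound 1 `COc1ccc(CCCCCCCCOc2ccc(CSc3cccc(C(=O)O)c3)nc2/C=C/C(=O)O)cc1`: 80 nM
Compound 2 `COc1ccc(CCCCCCCCOc2ccc(CSc3ccccc3)nc2/C=C/C(=O)O)cc1`: 74 nM

In an assay for binding affinity to leukotriene B4 receptor 1 (Homo sapiens) (on this read-out lower numbers stand for stronger inhibition and higher numbers for weaker inhibition), compound 1 gives 80 nM, while compound 2 gives 74 nM. Among the measured compounds shown here, compound 2 thus has the lower of the two numbers, but its only neighbour, compound 1, lies within the scatter of it, so the two cannot be told apart. For the measured compounds named here, the one measured step, a 1.1-fold lower number from compound 1 to compound 2 (0.03 log units; within the scatter), shows that the carboxy on this aromatic carbon of compound 1 made no difference beyond the scatter.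

Compound 3 `COc1ccc(CCCCCCCCOc2ccc(CSc3cccc(NC(=O)C(=O)O)c3)nc2/C=C/C(=O)O)cc1` differs from compound 2 by (carboxycarbonyl)amino in place of hydrogen on an aromatic carbon. Going by the values given here, the only step that bears on this change is the one from compound 1 to compound 2, which was within the scatter; a larger acidic group at the same site is therefore expected to move the number little, if at all. Compound 3 is expected to sit near compound 2, a step of a 1.2-fold lower number from compound 2 to compound 3 (0.09 log units; within the scatter). The estimate for compound 3 is 60 nM, with a range from 20 nM to 200 nM.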

Compound 3, inhibition constant: 72 nM
The estimate for compound 3 lay 1.2-fold (0.08 log units) below the measured number, within the range that was stated.
By their numbers in this assay, from the lowest: compounds 3, 2 and 1 (each within the scatter of the next).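

In this assay, the step from hydrogen to (carboxycarbonyl)amino reads a 1.0-fold lower number from compound 2 to compound 3 (0.01 log units; within the scatter), and the step from carboxy to (carboxycarbonyl)amino reads a 1.1-fold lower number from compound 1 to compound 3 (0.05 log units; within the scatter). Both lie within the scatter, so hydrogen, carboxy and the larger group of 6 heavy atoms cannot be told apart at this place on the six-membered aromatic ring, which extends the earlier result from one substituent to two. None of the data shown offers an explanation for this lack of separation.

On these data alone, whether an amine or a tetrazole at this place would also leave the number within the scatter remains open. As far as these compounds go, it is equally open whether (carboxycarbonyl)amino would read the same at another carbon of this ring, or on a compound with a shorter chain than the shared core carries.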